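Removing the Chloro Group on the Distal Ring

This account rests on a few compounds, and the source may have more. Where it says the series, first, only, none or still open, it means among the compounds named here.

Three compounds share a core in which an acid-bearing chain and an alkyne-linked aromatic ring sit on a chlorinated benzene. Compound 1 `CN(c1cccc(C#Cc2cc(Cl)ccc2OCC(=O)O)c1)S(C)(=O)=O` gives 122 nM in an assay on CHO cells for displacement of a labelled ligand from prostaglandin D2 receptor 2 (Homo sapiens), read by scintillation counting; on this read-out higher numbers stand for weaker inhibition and lower numbers for stronger inhibition. Compound 2 `O=C(O)COc1ccc(Cl)cc1C#Cc1cccc(C(F)(F)F)c1` gives 92 nM in this assay, and compound 3 `O=C(O)COc1ccc(Cl)cc1C#Cc1ccccc1Cl` gives 28 nM, the lowest of the three numbers. Within the data shown here, the only measured step, a 1.3-fold lower number from compound 1 to compound 2 (0.12 log units; within the scatter), exchanges one group for another on the distal ring and lies within the scatter.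

Compound 4 `O=C(O)COc1ccc(Cl)cc1C#Cc1ccccc1` differs from compound 3 by hydrogen in place of chloro on an aromatic carbon. Among the measured compounds shown here, no measured step removes a group outright, so there is no direct guide to the size of this change; the step from compound 1 to compound 2 only shows that swapping one group for another on that ring did little. Given that compound 3 stands clearly apart from compounds 1 and 2, the chloro may matter, and the expected outcome is a moderate weakening, a 2.9-fold higher number from compound 3 to compound 4 (0.46 log units; beyond the scatter), with compound 4 estimated at 80 nM, within a range of 30 nM to 220 nM.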

Compound 4, inhibition constant: 108 nM
Compound 4: the middle estimate sits 1.4-fold (0.13 log units) below what was measured; measured number inside the range.
By their numbers in this assay, from the lowest: compound 3; then compounds 2, 4 and 1 (each within the scatter of the next).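

Taking the chloro away, ortho to a large group, gives a 3.9-fold higher number from compound 3 to compound 4 (0.59 log units; beyond the scatter) in this assay, the first measured step in this series that lies beyond the scatter. Plain phenyl also sits level with the two compounds carrying larger groups, as shown by a 1.2-fold higher number from compound 2 to compound 4 (0.07 log units; within the scatter) and by a 1.1-fold lower number from compound 1 to compound 4 (0.05 log units; within the scatter), so trifluoromethyl and methyl(methylsulfonyl)amino show no measurable difference from hydrogen, and among these four compounds only the 2-chlorophenyl group stands apart. No measurement available here explains why the chloro has this effect.

As far as these compounds go, whether this lower number needs chlorine itself, or would also come with a fluoro, a bromo or a methyl at the same place, stays open. So does whether a second chloro on that ring would lower the number further.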